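Series notes: chloro in place of methoxy on the benzyl ring

The source may hold more compounds than are shown below. What is called first, only, known or untested is meant among the compounds shown, and "the series" means these compounds.

Within the data shown here, compound 3 `COc1ccc(Cc2cnc(CCc3ccc(-c4ccccc4C(=O)O)cc3)[nH]2)cc1` gives 5360 nM in an in vitro functional assay on cells for agonist activity at Bombesin receptor subtype-3 (Homo sapiens), read by luminescence and calcium flux (on this read-out higher numbers stand for an effect only at larger amounts of compound and lower numbers for an effect already at smaller amounts), the highest of the three numbers measured so far. Compound 1 `O=C(O)c1ccccc1-c1ccc(CCc2ncc(CC3CCCCC3)[nH]2)cc1` gives 41 nM in this assay, and compound 2 `Cc1ccccc1Cc1cnc(CCc2ccc(-c3ccccc3C(=O)O)cc2)[nH]1` gives 127 nM. The steps between them are all beyond the scatter: a 3.1-fold higher number from compound 1 to compound 2 (0.49 log units; beyond the scatter); a 130-fold higher number from compound 1 to compound 3 (2.12 log units; beyond the scatter); a 42-fold higher number from compound 2 to compound 3 (1.63 log units; beyond the scatter). Compound 3 thus stands well apart from the other two.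

Compound 4 `O=C(O)c1ccccc1-c1ccc(CCc2ncc(Cc3ccc(Cl)cc3)[nH]2)cc1` differs from compound 3 by chloro in place of methoxy on an aromatic carbon. Among the measured compounds shown here, none of the measured steps alters a single substituent on this ring; each swaps the whole group on the saturated chain carbon. They show only that 4-methoxyphenyl at that position gives a much higher number than either 2-methylphenyl or cyclohexyl. Whether chloro at the same place tracks methoxy or moves the number back toward compound 1 and compound 2 cannot be read from them, so the expectation is uncertain in size but leans toward a lower number. For compound 4 the expected step is a 6.0-fold lower number from compound 3 to compound 4 (0.77 log units; beyond the scatter). The estimated value for compound 4 in this assay is 900 nM, with a range from 150 nM to 5000 nM.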

Compound 4, half-maximal effective concentration: 2290 nM
For compound 4 the middle estimate is 2.5-fold (0.41 log units) below the measured one, within the range that was stated.
By their numbers in this assay, from the lowest: compound 1; then compound 2; then compound 4; then compound 3.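

In this assay, changing only the group para to a large group on the benzyl ring gives a 2.3-fold lower number from compound 3 to compound 4 (0.37 log units; beyond the scatter), so this ring place responds to a single substituent swap, though only modestly. The larger gaps remain with the new group, at an 18-fold higher number from compound 2 to compound 4 (1.26 log units; beyond the scatter) and a 56-fold higher number from compound 1 to compound 4 (1.75 log units; beyond the scatter), so among the two 4-substituted benzyl compounds, both methoxy and chloro leave the number far above those of compound 1 and compound 2. No measurement at hand accounts for either the modest step or the larger gaps.

The compounds shown do not separate the effect of where the substituent sits from the effect of which substituent it is, since compound 2 carries a methyl on a different ring place from the groups in compound 3 and compound 4. An unsubstituted phenyl, a 4-methylphenyl or a 2-chlorophenyl in the same position would be needed to tell whether the high numbers follow the 4-substituted pattern generally or only methoxy and chloro.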